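This account rests on a few compounds, and the source may have more. Where it says the series, first, only, none or still open, it means among the compounds named here.

In a functional assay on OVCAR-3 cells (Homo sapiens) for cytotoxicity, read by sulforhodamine B assay (a higher number here means a weaker inhibitor of growth, a lower number a stronger inhibitor of growth), compound 1 `CC1=CC[C@@H]([C@@](C)(O)CCCC(C)(C)NC(=S)N/N=C\c2ccccc2)CC1` gives 12900 nM as its concentration for total growth inhibition. Compound 2 `CC1=CC[C@@H]([C@@](C)(O)CCCC(C)(C)NC(=S)N/N=C\c2ccc(O)cc2)CC1` gives 17400 nM as its reading, which lies within the scatter of compound 1. Compound 3 `CC1=CC[C@@H]([C@@](C)(O)CCCC(C)(C)NC(=S)N/N=C\c2ccc(N(C)C)cc2)CC1` gives > 100000 nM and this is a limit of the assay, not a number. Compound 1 thus shares the stronger end of this short series with compound 2.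

Compound 4 `CC1=CC[C@@H]([C@@](C)(O)CCCC(C)(C)NC(=S)N/N=C\c2ccccc2[N+](=O)[O-])CC1` keeps the core of compound 1 and carries nitro in place of hydrogen on an aromatic carbon, ortho to a large group, with nitro in place of hydrogen on an aromatic carbon as the counted difference. Two measured steps also replace a hydrogen on that aromatic ring. Hydroxy in compound 2 gave a 1.3-fold higher number from compound 1 to compound 2 (0.13 log units; within the scatter) as its step, while dimethylamino in compound 3 gave an at least 7.7-fold higher number from compound 1 to compound 3 (0.88 log units; beyond the scatter) as its step. Neither group is nitro and the two steps disagree, so they offer only loose guidance. In this assay a step within the scatter is therefore expected, with some lean toward a higher number, meaning weaker growth inhibition. For compound 4 the expected value is 16000 nM with an estimated range from 6000 nM to 60000 nM as the likely span. That estimate means a 1.2-fold higher number from compound 1 to compound 4 (0.09 log units; within the scatter) as the expected step.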

Compound 4, concentration for total growth inhibition: 16200 nM
For compound 4 the middle estimate is 1.0-fold (0.01 log units) below the measured one; the measured number falls inside the stated range.
By their numbers in this assay, from the lowest: compounds 1, 4 and 2 (each within the scatter of the next). At a limit, above all of these: compound 3.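

In this assay, nitro on an aromatic carbon, ortho to a large group, gives a 1.3-fold higher number from compound 1 to compound 4 (0.10 log units; within the scatter), and the comparison with the hydroxy compound gives a 1.1-fold lower number from compound 2 to compound 4 (0.03 log units; within the scatter), so compound 1, compound 2 and compound 4 cannot be told apart in this assay, and a hydrogen at this place can give way to nitro with no measurable cost in growth inhibition. The dimethylamino compound stays apart from this group, with an at least 6.1-fold lower number from compound 3 to compound 4 (0.79 log units; beyond the scatter), so among the four compounds it alone goes beyond the scatter, and 2-nitrophenyl does not share its loss of growth inhibition. The reading for compound 3 is a limit of the assay and not a number, so the true size of that step stays unknown: the limit of > 100000 nM in this assay, at which 1 of the 4 values shown sits.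

Still open, from the compounds shown here alone, is whether this tolerance belongs to nitro or to the place on the ring, since an amine, a methoxy group or a chlorine at the same place would separate those two readings. Going by these compounds alone, a carboxylic acid on the ring would also test how far the acceptance of new groups extends, given that dimethylamino is the only group here that goes beyond the scatter.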